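Replacing benzyloxy with methyl in a growth-inhibition series

The source may hold more compounds than are shown below. What is called first, only, known or untested is meant among the compounds shown, and "the series" means these compounds.

Values in a functional assay on U-373MG ATCC cells (Homo sapiens) for inhibition, read by MTT assay, with a stated time of 72 h; on this read-out higher numbers stand for weaker inhibition of growth and lower numbers for stronger inhibition of growth:
Compound 1 `CC1(C)CCC[C@]2(C)[C@@H](C=O)C(C=O)=CC[C@@H]12`: > 100000 nM, a limit of the assay and not a number
Compound 2 `COC(=O)/C=C/C1=CC[C@H]2C(C)(C)CCC[C@]2(C)[C@H]1C=O`: 22000 nM
Compound 3 `CC1(C)CCC[C@]2(C)[C@@H](C=O)C(/C=C/C(=O)OCc3ccccc3)=CC[C@@H]12`: 39000 nM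

Compound 3 gives 39000 nM and compound 2 gives 22000 nM, two values within the usual scatter of each other. Among the numbers available, compound 3 therefore stands level with compound 2.

Compound 4 `CC(=O)/C=C/C1=CC[C@H]2C(C)(C)CCC[C@]2(C)[C@H]1C=O` carries methyl in place of benzyloxy on a carbonyl carbon whose other neighbours are: double-bonded chain carbon (methyl in place of benzyloxy on a carbonyl carbon). The closest measured change at this end of the molecule is a 1.8-fold higher number from compound 2 to compound 3 (0.25 log units; within the scatter), with phenyl in place of hydrogen on a saturated chain carbon bound to an oxygen next to a carbonyl group. That step stayed within the scatter. The other step, an at least 4.5-fold lower number from compound 1 to compound 2 (0.65 log units; beyond the scatter), starts from a limit and brought in 2-(methoxycarbonyl)ethenyl in place of formyl on a double-bonded ring carbon. Compound 4 keeps the double-bonded chain carbon on its carbonyl carbon, so this gain is expected to persist.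

In this assay, the estimated change is a 1.8-fold lower number from compound 3 to compound 4 (0.25 log units; within the scatter), and no step beyond the scatter is expected. For compound 4 the estimate is 22000 nM, with an expected range of 9000 nM to 55000 nM.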

Compound 4, concentration for 50% growth inhibition: 25000 nM
Compound 4: middle estimate off by 1.1-fold (0.06 log units), on the low side, and the stated range covers the measured number.
By their numbers in this assay, from the lowest: compounds 2, 4 and 3 (each within the scatter of the next). At a limit, above all of these: compound 1.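

In this assay, methyl on the carbonyl carbon reads level with benzyloxy (a 1.6-fold lower number from compound 3 to compound 4 (0.19 log units; within the scatter)) and with methoxy (a 1.1-fold higher number from compound 2 to compound 4 (0.06 log units; within the scatter)), so at this place neither the ester oxygen nor the aromatic ring of benzyloxy is needed to keep the number in this range. Compound 1 stands at a limit of the assay and not a number (> 100000 nM). The gain seen with the 2-(methoxycarbonyl)ethenyl group also appears with 2-acetylethenyl, so it does not depend on an ester, though its size can be read only as a bound because the step starts from that limit (an at least 4.0-fold lower number from compound 1 to compound 4 (0.60 log units; beyond the scatter)): the limit of > 100000 nM in this assay, at which 1 of the 4 values shown sits.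

The compounds shown leave open whether a carboxylic acid, an amide or a longer alkyl chain on this carbonyl carbon would also stay level with methyl, or would move the number beyond the scatter. They also leave open whether the carbonyl itself matters, since all of compounds 2, 3 and 4 keep it, and a saturated chain or an amine in place of the ethenyl carbonyl unit has no value here.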